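Adding fluoro to the phenyl of compound 3

The compounds below may be only part of what the source reports. "The series", "measured", "known", "first", "only" and "open" are said of these compounds alone.

In a functional assay on A2780 cells (Homo sapiens) for antiproliferative activity, read by MTT assay, with a stated time of 72 h (on this read-out lower numbers stand for stronger inhibition and higher numbers for weaker inhibition), compound 1 (`COc1ccc(C2CC(c3ccccc3)=NN2C(=O)c2cc3ccccc3o2)cc1OC`) gives 6.89 ug/mL, compound 2 (`O=C(c1cc2ccccc2o1)N1N=C(c2ccccc2)CC1c1ccc(Cl)cc1`) gives 5.13 ug/mL and compound 3 (`O=C(c1cc2ccccc2o1)N1N=C(c2ccccc2)CC1c1ccccc1Cl`) gives 6.22 ug/mL, so compound 3 stands within the scatter of both others.

Compound 4 (`O=C(c1cc2ccccc2o1)N1N=C(c2ccc(F)cc2)CC1c1ccccc1Cl`) differs from compound 3 by fluoro in place of hydrogen on an aromatic carbon: phenyl to 4-fluorophenyl, para to a large group.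

Among the compounds with values here, no measured step changes this group. The nearest evidence is the group on a saturated ring carbon, with steps of a 1.3-fold lower number from compound 1 to compound 2 (0.13 log units; within the scatter), a 1.1-fold lower number from compound 1 to compound 3 (0.04 log units; within the scatter) and a 1.2-fold higher number from compound 2 to compound 3 (0.08 log units; within the scatter).

From these small steps, no change beyond the scatter is expected in this assay, in either direction. The expected step is a 1.0-fold lower number from compound 3 to compound 4 (0.02 log units; within the scatter). Compound 4 is estimated at 6 ug/mL, with an expected range of 3.2 ug/mL to 11 ug/mL.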

Compound 4, half-maximal inhibitory concentration: 45.2 ug/mL
For compound 4 the middle estimate is 7.5-fold (0.88 log units) below the measured one; the whole stated range lies below it.
By their numbers in this assay, from the lowest: compounds 2, 3 and 1 (each within the scatter of the next); then compound 4.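

This position is not silent: in this assay the change gives a 7.3-fold higher number from compound 3 to compound 4 (0.86 log units; beyond the scatter) while the three earlier changes, all on the saturated ring carbon, stayed within the scatter. A single fluoro on this phenyl, para to a large group, therefore moves the number further than any aryl exchange shown so far. Nothing measured here accounts for the step.

Whether the step is specific to fluoro remains open, with chloro, methoxy or an amine at this place absent from the compounds shown. Also open, as far as these compounds go, is whether 4-fluorophenyl has the same effect alongside the other aryl groups of compound 1 and compound 2.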